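Adding a Second Ester Group to a Stable Scaffold

The source may report more compounds than this note shows. Statements on the series, on what has been measured and on what is new or still open speak of the compounds shown alone.

Three measured compounds share one core and differ only in the ester group at one end. Compound 1 `CCOC(=O)OCOC(=O)C1=C(S[C@@H]2CN[C@H](C(=O)Nc3cccc(C(=O)O)c3)C2)[C@H](C)[C@@H]2[C@@H]([C@@H](C)O)C(=O)N12` carries an ethoxy group there; in a physicochemical assay for metabolic stability, read by LC-MS, in phosphate buffer, with a stated time of 3 h, at pH 7.4, tested at 50 uM (on this read-out lower numbers stand for a less stable compound and higher numbers for a more stable compound), compound 1 gives > 95%, which is a limit of the assay rather than a number. Compound 2 `CCC(CC)C(=O)OCOC(=O)C1=C(S[C@@H]2CN[C@H](C(=O)Nc3cccc(C(=O)O)c3)C2)[C@H](C)[C@@H]2[C@@H]([C@@H](C)O)C(=O)N12` has pentan-3-yl in that place, and in this assay compound 2 gives > 95%, again a limit. Compound 3 `C[C@@H](O)[C@H]1C(=O)N2C(C(=O)OCOC(=O)OC(C)(C)C)=C(S[C@@H]3CN[C@H](C(=O)Nc4cccc(C(=O)O)c4)C3)[C@H](C)[C@H]12` carries tert-butyl on the oxygen next to the carbonyl group, and in this assay compound 3 gives > 95%, also a limit. Accordingly a step that the two limits leave unreadable from compound 1 to compound 2, a step that the two limits leave unreadable from compound 1 to compound 3 and a step that the two limits leave unreadable from compound 2 to compound 3; all three values rest at the same point, (the limit of > 95% in this assay, at which 3 of the 3 values shown sit), so compound 3 stands level with the other two as far as the read-out can tell.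

Compound 4 `C[C@@H](O)[C@H]1C(=O)N2C(C(=O)OCOC(=O)OC(C)(C)C)=C(S[C@@H]3CN[C@H](C(=O)Nc4cccc(C(=O)OCOC(=O)OC(C)(C)C)c4)C3)[C@H](C)[C@H]12` differs from compound 3 by ((tert-butoxycarbonyl)oxy)methyl in place of hydrogen on an oxygen next to a carbonyl group. Among the compounds with values here, no measured step touches this position, and the steps among the ester groups gave no readable size. The expectation is therefore that compound 4 stays close to the limit, with a number at least 2 percentage points lower from compound 3 to compound 4 (that floor lies within the scatter) expected to be none beyond the scatter. Compound 4 is estimated at 93%, between 80% and 98%.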

Compound 4, percent of the compound remaining: > 95%
Compound 4: no number, only a limit; the forecaster's own chance of this, stated with the estimate: 60%; middle value at least 2 percentage points away from the limit.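

In this assay compound 4 gives > 95%, which is a limit of the assay rather than a number. No size can be read for the change from compound 3 to compound 4, since both values rest at the same point: the limit of > 95% in this assay, at which 4 of the 4 values shown sit.

The compounds shown leave open whether compound 1, compound 2, compound 3 and compound 4 differ from one another at all in this assay.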